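The source may report more compounds than this note shows. Statements on the series, on what has been measured and on what is new or still open speak of the compounds shown alone.

In a toxicity assay on NIH3T3 cells (Mus musculus) for cytotoxicity, read by resazurin assay (on this read-out lower numbers stand for an effect already at smaller amounts and higher numbers for an effect only at larger amounts of compound), compound 1 (`c1ccc(-c2ccc(Cn3cncc3CNc3cccc(-c4ccccc4)c3)cc2)cc1`) gives 10000 nM as a measured number. Compound 2 (`CCCC(=O)c1ccc(NCc2cncn2Cc2ccc(-c3ccccc3)cc2)cc1-c1ccccc1`) gives > 10000 nM as a limit of the assay and not a number. Compound 3 (`c1ccc(-c2ccc(Cn3cncc3CNc3ccc(N4CCCCC4)c(-c4ccccc4)c3)cc2)cc1`) has piperidin-1-yl in place of the propylcarbonyl of compound 2 on an aromatic carbon (piperidin-1-yl in place of propylcarbonyl on an aromatic carbon). For the measured compounds named here, the only measured step at this place, with propylcarbonyl in place of hydrogen (a number no lower from compound 1 to compound 2 (the limit leaves the size open)), has no readable size and sets no expected direction. The expected change in this assay is therefore none beyond the scatter (a number no higher from compound 2 to compound 3 (the limit leaves the size open)). Compound 3 is estimated at 10000 nM with an expected range of 3000 nM to 30000 nM in this read-out.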

Compound 3, half-maximal effective concentration: > 1000 nM
Compound 3: a limit, no number; the forecaster's own chance of this, stated with the estimate: 55%; the middle value does not contradict the limit.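

In this assay compound 3 gives > 1000 nM, a limit and not a number, so its steps from compound 1 and compound 2 cannot be read. From the compounds shown here alone, whether piperidin-1-yl in place of propylcarbonyl or hydrogen changes the value in this assay stays open.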